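From ethoxy to (4-chlorophenyl)amino against a flat limit

The compounds below may be only part of what the source reports. "The series", "measured", "known", "first", "only" and "open" are said of these compounds alone.

In a functional assay on HT-29 cells (Homo sapiens) for inhibition, read by MTT assay, with a stated time of 48 h (on this read-out lower numbers stand for stronger inhibition and higher numbers for weaker inhibition), compound 1 `COc1ccc(C(=O)CSc2nnc(-c3cc(OC)c(OC)c(OC)c3)n2-c2ccc(OC)cc2)cc1` gives > 60000 nM, which is a limit. Compound 2 `COc1ccc(-n2c(SCC(=O)c3ccc(OC)c(O)c3)nnc2-c2cc(OC)c(OC)c(OC)c2)cc1` gives > 60000 nM, also a limit. Compound 3 `CCOC(=O)CSc1nnc(-c2cc(OC)c(OC)c(OC)c2)n1-c1ccc(OC)cc1` gives > 60000 nM, again a limit and not a number. Compound 3 thus stands with the other two, at the limit of > 60000 nM in this assay, at which 3 of the 3 values shown sit.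

Compound 4 `COc1ccc(-n2c(SCC(=O)Nc3ccc(Cl)cc3)nnc2-c2cc(OC)c(OC)c(OC)c2)cc1` differs from compound 3 in one place: (4-chlorophenyl)amino in place of ethoxy on a carbonyl carbon. This puts (4-chlorophenyl)amino in place of ethoxy on a carbonyl carbon.

Two measured steps change that same carbon: a step that the two limits leave unreadable from compound 1 to compound 3 and a step that the two limits leave unreadable from compound 2 to compound 3. Neither has a readable size, so this assay shows no measured effect of this exchange in either direction. Compound 1, with 4-methoxyphenyl on that carbonyl carbon, still gives > 60000 nM, so an aromatic ring there did not bring a readable number in compound 1.

No large gain is expected, and the estimated step is an at least 1.2-fold lower number from compound 3 to compound 4 (0.07 log units; that floor lies within the scatter). Compound 4 may well be reported only as a limit. Compound 4 is estimated at 50000 nM, with an expected range from 12000 nM to 90000 nM.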

Compound 4, half-maximal inhibitory concentration: 58000 nM
Compound 4: middle estimate off by 1.2-fold (0.06 log units), on the low side; the measured number falls inside the stated range.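

With (4-chlorophenyl)amino on the carbonyl carbon, compound 4 is the only one of the four to give a readable number in this assay, and the other three are limits and not numbers: the limit of > 60000 nM in this assay, at which 3 of the 4 values shown sit.

In place of ethoxy the exchange gives an at least 1.0-fold lower number from compound 3 to compound 4 (0.01 log units; that floor lies within the scatter), in place of 3-hydroxy-4-methoxyphenyl it gives an at least 1.0-fold lower number from compound 2 to compound 4 (0.01 log units; that floor lies within the scatter), and in place of 4-methoxyphenyl it gives an at least 1.0-fold lower number from compound 1 to compound 4 (0.01 log units; that floor lies within the scatter). Each of these is only a floor, so this carbonyl carbon now has one number to its name, but no gain beyond the scatter is shown, and how far compound 4 truly lies from the other three stays unknown.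

It stays open whether the chlorine contributes anything, since the compounds shown do not tell what a plain phenylamino would give on that carbonyl carbon. They also leave open what a carboxylic acid or a morpholine there would give.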